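Ethynyl in place of thiophen-2-yl on the shared core

The compounds below may be only part of what the source reports. "The series", "measured", "known", "first", "only" and "open" are said of these compounds alone.

Measured in an ADME assay on BJ cells (Homo sapiens), read by MTT assay, with a stated time of 72 h; a lower number here means a stronger inhibitor, a higher number a weaker inhibitor:
compound 1 `COc1ncnc2c1c(-c1cccs1)cn2[C@@H]1O[C@H](CO)[C@@H](O)[C@H]1O` gives 62800 nM
compound 3 `CSc1ncnc2c1c(-c1cccs1)cn2[C@@H]1O[C@H](CO)[C@@H](O)[C@H]1O` gives 96900 nM
compound 2 `CNc1ncnc2c1c(-c1cccs1)cn2[C@@H]1O[C@H](CO)[C@@H](O)[C@H]1O` reaches only a limit, > 100000 nM

Compound 1 has the lowest of the two numbers; its nearest neighbour is compound 3, with a 1.5-fold higher number from compound 1 to compound 3 (0.19 log units; within the scatter). For compound 2 the assay gives a limit rather than a number, so from compound 1 the step is an at least 1.5-fold higher number from compound 1 to compound 2 (0.20 log units; that floor lies within the scatter), and from compound 2 to compound 3 it is an at least 1.0-fold lower number from compound 2 to compound 3 (0.01 log units; that floor lies within the scatter). One of the three values thus sits at the limit of > 100000 nM in this assay, at which 1 of the 3 values shown sits. Across the three measured compounds, which differ only in the methoxy, methylamino or methylsulfanyl group on an aromatic carbon, no step leaves the scatter.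

Compound 4 `C#Cc1cn([C@@H]2O[C@H](CO)[C@@H](O)[C@H]2O)c2ncnc(OC)c12` differs from compound 1 elsewhere on the shared core: ethynyl in place of thiophen-2-yl on an aromatic carbon. Among the compounds with values here, none of the measured steps touches the group on the five-membered aromatic ring, so no measured step bears on this change, and the size of its effect in this assay cannot be read from the numbers in hand. Given that, the expectation for compound 4 is a number close to that of compound 1, with the step of a 1.3-fold lower number from compound 1 to compound 4 (0.10 log units; within the scatter) regarded as uncertain in both directions. Compound 4 is therefore estimated at 50000 nM, within a wide range from 10000 nM to 150000 nM.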

Compound 4, half-maximal inhibitory concentration: 98400 nM
The estimate for compound 4 lay 2.0-fold (0.29 log units) below the measured number; low and high end bracket the measured number.
By their numbers in this assay, from the lowest: compounds 1, 3 and 4 (each within the scatter of the next). At a limit, above all of these: compound 2.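

In this assay, the change at this aromatic carbon, two ring bonds from the ring nitrogen, gives a 1.6-fold higher number from compound 1 to compound 4 (0.20 log units; within the scatter). With the methoxy group held constant, this pair therefore shows no separation when thiophen-2-yl, a five-membered aromatic ring, gives way to ethynyl, which has no ring and carries a triple bond. Within the data shown here, the earlier compounds varied only the methoxy, methylamino or methylsulfanyl group, so this is the first reading at this position, and none of the data on hand gives a measured property that bears on this step.

From the compounds shown here alone, whether ethynyl and thiophen-2-yl also stay within the scatter of each other alongside methylamino or methylsulfanyl remains open, since this comparison rests on a single pair with the methoxy group. Also open, going by these compounds, is whether a phenyl ring, a longer chain such as prop-1-ynyl, an amine or a carboxylic acid on this carbon would give a step beyond the scatter from compound 1.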